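The source may report more compounds than this note shows. Statements on the series, on what has been measured and on what is new or still open speak of the compounds shown alone.

Measured so far:
Compound 1, `C=C[C@@](C)(CC[C@H]1C(C)=CC[C@H]2C(C)(C)CCC[C@]12C)O[C@@H]1O[C@H](C)[C@H](OC(C)=O)[C@H](O)[C@H]1O`: 5.8 ug/mL
Compound 2, `C=C[C@@](C)(CC[C@@H]1[C@@]2(C)CCCC(C)(C)[C@@H]2CC[C@@]1(C)O)O[C@H]1O[C@H](C)[C@H](O)[C@@H](O)[C@@H]1O`: > 5 ug/mL

In a functional assay on SK-OV-3 cells (Homo sapiens) for cytotoxicity, read by sulforhodamine B assay (a higher number here means that more compound is needed for the effect, a lower number that less compound is needed), compound 1 gives 5.8 ug/mL. Compound 2 returns > 5 ug/mL, which is a limit of this assay and not a number. Compound 2 thus stands at the limit of > 5 ug/mL in this assay, at which 1 of the 2 values shown sits. The step to compound 3, `C=C[C@@](C)(CC[C@@H]1[C@@]2(C)CCCC(C)(C)[C@@H]2CC[C@@]1(C)O)O[C@@H]1O[C@H](C)[C@H](O)[C@H](O)[C@H]1O`, changes no atom and no bond: the two compounds have the same atoms and bonds and differ only in configuration as drawn: 3 of 10 stereo elements differ; a stereocentre at a saturated ring carbon is drawn R in compound 2 and S in compound 3; a stereocentre at a saturated ring carbon is drawn R in compound 2 and S in compound 3; a stereocentre at a saturated ring carbon is drawn S in compound 2 and R in compound 3. Among the measured compounds shown here, no step between two measured compounds is available, so nothing measured here shows how a change of configuration alone moves the read-out in this assay. Compound 3 is expected to stay in the same region as the pair already measured, with an expected step that the limit leaves unreadable from compound 2 to compound 3, none beyond the scatter. The estimate for compound 3 in this assay is 6 ug/mL, expected to fall between 3 ug/mL and 15 ug/mL.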

Compound 3, concentration for half-maximal effect: > 5 ug/mL
Compound 3: only a limit was reported; the forecaster's own chance of this, stated with the estimate: 50%; the middle value lies beyond the limit too.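

Compound 2 and compound 3 both stand at a limit and not at a number in this assay, so no step between them can be read: the limit of > 5 ug/mL in this assay, at which 2 of the 3 values shown sit.

The compounds shown leave open whether this change of configuration alone moves the read-out, and where either compound truly lies past that limit.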